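Chain Extension on Two Related Cores: Cytotoxicity Notes

This account rests on a few compounds, and the source may have more. Where it says the series, first, only, none or still open, it means among the compounds named here.

Compound 1 `CCCCCCCc1cc2cn(COCCO)c(O)nc-2n1` and compound 2 `CCCCCCCCCc1cc2cn(COCCO)c(O)nc-2n1` share one core; compound 3 `CCCCCCCc1cc2cn(COCCO)c(=O)nc2o1` and compound 4 `CCCCCCCCCc1cc2cn(COCCO)c(=O)nc2o1` share another. The difference between the two cores is not broken down here. In a functional assay on HEL cells (Homo sapiens), read by microscopy (on this read-out lower numbers stand for higher toxicity in this test and higher numbers for lower toxicity in this test), compound 1 gives >= 400000 nM, which is a limit of the assay and not a number. In this assay compound 2 gives > 80000 nM, also a limit. Between the two stands (ethyl in place of hydrogen on a saturated chain carbon, seven bonds along the chain from an aromatic carbon); the step that the two limits leave unreadable from compound 1 to compound 2 is bounded by the limit of >= 400000 nM in this assay, at which 1 of the 3 values shown sits, and (the limit of > 80000 nM in this assay, at which 1 of the 3 values shown sits), so its size is not readable. In this assay, among the compounds with values here, compound 3 gives 400000 nM, the only value in the set that is a number. Compound 4 is not yet measured in this assay. It carries the same change as before, (ethyl in place of hydrogen on a saturated chain carbon, seven bonds along the chain from an aromatic carbon), on the core of compound 3. Within the data shown here, the one measured instance of this change gives no size. The expectation for compound 4 rests on compound 3 at 400000 nM alone. The step of no change at the digits printed from compound 3 to compound 4 (within the scatter) is expected to be small. Compound 4 is estimated at 400000 nM in this assay, between 100000 nM and 1000000 nM.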

Compound 4, minimum cytotoxic concentration: >= 16000 nM
Compound 4 ended at the assay's limit (the forecaster's own chance of this, stated with the estimate: 60%); the middle value lies beyond the limit too.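

In this assay compound 4 gives >= 16000 nM, which is a limit of the assay and not a number. In this assay compound 3 gives 400000 nM, so no size can be read for the step between compound 3 and compound 4. The compounds shown leave open how much the change from hydrogen to ethyl shifts the read-out on either core.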